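From 2,3,4-Trihydroxybutyl to a Hydroxymethyl-Bearing Chain

The source may hold more compounds than are shown below. What is called first, only, known or untested is meant among the compounds shown, and "the series" means these compounds.

In a functional assay on MIA PaCa-2 cells (Homo sapiens) for cytotoxicity, read by MTT assay, with a stated time of 24 h (on this read-out lower numbers stand for stronger inhibition and higher numbers for weaker inhibition), compound 2 (`CC[C@H](C)[C@@H](O)C(=O)O[C@@H](C(=O)O[C@@H](C(=O)O[C@@H](C(=O)O[C@@H](C(=O)OC[C@@H](O)[C@@H](O)CO)[C@@H](C)CC)[C@@H](C)CC)[C@@H](C)CC)[C@@H](C)CC`) stands only at a limit (> 57800 nM). Compound 1 (`CC[C@H](C)[C@@H](O)C(=O)O[C@@H](C(=O)O[C@@H](C(=O)O[C@@H](C(=O)O[C@@H](C(=O)OC[C@@H](O)[C@@H](O)[C@H](O)CO)[C@@H](C)CC)[C@@H](C)CC)[C@@H](C)CC)[C@@H](C)CC`) also gives only a limit (> 55400 nM). Compound 3 (`CC[C@H](C)[C@@H](O)C(=O)O[C@@H](C(=O)O[C@@H](C(=O)O[C@@H](C(=O)O[C@@H](C(=O)OC[C@@H](O)[C@@H](O)[C@H](O)[C@H](O)CO)[C@@H](C)CC)[C@@H](C)CC)[C@@H](C)CC)[C@@H](C)CC`) likewise gives only a limit (> 53200 nM). Compound 4 (`CC[C@H](C)[C@@H](O)C(=O)O[C@@H](C(=O)O[C@@H](C(=O)O[C@@H](C(=O)O[C@@H](C(=O)O[C@H](CO)[C@@H](O)[C@H](O)CO)[C@@H](C)CC)[C@@H](C)CC)[C@@H](C)CC)[C@@H](C)CC`) differs from compound 2 on an oxygen next to a carbonyl group, where 2,3,4-trihydroxy-1-(hydroxymethyl)butyl replaces 2,3,4-trihydroxybutyl (2,3,4-trihydroxy-1-(hydroxymethyl)butyl in place of 2,3,4-trihydroxybutyl on an oxygen next to a carbonyl group). Two measured changes on this same chain bear on it (a step that the two limits leave unreadable from compound 1 to compound 2) and (a step that the two limits leave unreadable from compound 2 to compound 3), and neither has a readable size. No step beyond the usual scatter is therefore expected in this assay, and another limit is the likeliest result. The expected step is (an at least 1.0-fold lower number from compound 2 to compound 4 (0.02 log units; that floor lies within the scatter)). Compound 4 is estimated at 55000 nM with an expected range from 35000 nM to 100000 nM.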

Compound 4, half-maximal inhibitory concentration: 36400 nM
Compound 4: the middle estimate sits 1.5-fold (0.18 log units) above what was measured, and the stated range covers the measured number.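

Among these compounds, on an oxygen next to a carbonyl group, 2,3,4-trihydroxy-1-(hydroxymethyl)butyl brings the first reading that is not a limit: in this assay compound 4 gives 36400 nM as a true number. The comparisons read as an at least 1.5-fold lower number from compound 2 to compound 4 (0.20 log units; that floor lies within the scatter) and an at least 1.4-fold lower number from compound 3 to compound 4 (0.16 log units; that floor lies within the scatter) and an at least 1.5-fold lower number from compound 1 to compound 4 (0.18 log units; that floor lies within the scatter), each a floor that lies within the scatter, so a real change is not established. Nothing measured here gives a cause for this change. Still open, as far as these compounds go, are the true size of these steps and how an amine or a carboxylic acid in place of the hydroxymethyl would read.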